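Aryl substituent and macrophage cytotoxicity across three measured compounds

The compounds below may be only part of what the source reports. "The series", "measured", "known", "first", "only" and "open" are said of these compounds alone.

Measured in an ADME assay on J774.A1 cells (Mus musculus) for cytotoxicity, read by MTT assay, with a stated time of 48 h; on this read-out lower numbers stand for higher toxicity in this test and higher numbers for lower toxicity in this test:
- compound 1 `CCOC(=O)c1[nH]c(=O)c(C#N)cc1C(=O)c1ccccc1`: 215000 nM
- compound 2 `CCOC(=O)c1[nH]c(=O)c(C#N)cc1C(=O)c1ccc(F)cc1`: < 100000 nM, a limit of the assay
- compound 3 `CCOC(=O)c1[nH]c(=O)c(C#N)cc1C(=O)c1ccc(OC)cc1`: < 100000 nM, a limit of the assay

Compound 3 stands at the limit of this assay, not at a number, and compound 2 sits at the same limit, (the limit of < 100000 nM in this assay, at which 2 of the 3 values shown sit). Only compound 1 gives a read number. Both substitutions on the aromatic ring moved the read-out below that limit: an at least 2.1-fold lower number from compound 1 to compound 2 (0.33 log units; beyond the scatter) and an at least 2.1-fold lower number from compound 1 to compound 3 (0.33 log units; beyond the scatter). The pair of limits leaves a step that the two limits leave unreadable from compound 2 to compound 3, so nothing separates fluoro from methoxy here.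

Compound 4 `CCOC(=O)c1[nH]c(=O)c(C#N)cc1C(=O)c1ccc(Br)cc1` carries the next change: bromo in place of methoxy on an aromatic carbon. Two different groups para to a large group each took the number below the limit, and bromo is expected to behave in the same way, so the estimated step that the limit leaves unreadable from compound 3 to compound 4 is none beyond the scatter. Compound 4 is expected to give about 70000 nM in this assay, within 30000 nM to 160000 nM, most likely again reported only as the limit.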

Compound 4, half-maximal cytotoxic concentration: < 100000 nM
Compound 4: a limit, no number (the forecaster's own chance of this, stated with the estimate: 60%); the middle value does not contradict the limit.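

In this assay, bromo on the aromatic carbon para to a large group repeats what fluoro and methoxy gave at this position: an at least 2.1-fold lower number from compound 1 to compound 4 (0.33 log units; beyond the scatter). Within the data shown here, all three groups tested in place of hydrogen there now point the same way, with no compound going against this, while the steps among compound 2, compound 3 and compound 4 cannot be read. Compound 4 gives only a limit, not a number, and the series now sits mostly at that limit: the limit of < 100000 nM in this assay, at which 3 of the 4 values shown sit.

From the compounds shown here alone, how far compound 2, compound 3 and compound 4 lie past the limit stays open, and with it any order among fluoro, methoxy and bromo. Also open, going by these compounds, is whether an amine or a carboxylic acid at this position would stay close to compound 1 or reach the limit as well.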